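The compounds below may be only part of what the source reports. "The series", "measured", "known", "first", "only" and "open" are said of these compounds alone.

Of the compounds shown here, three have been measured in an assay on HT-29 cells for inhibition of Serine-protein kinase ATM (Homo sapiens), read by fluorescence, with a stated time of 1 h; on this read-out higher numbers stand for weaker inhibition and lower numbers for stronger inhibition. Compound 1 `C[C@@H](Nc1ccnc2ccc(-c3cccnc3)cc12)c1ccc(Cl)cc1` returns only a limit in this assay, > 30000 nM, and that limit is the ceiling of the measurement (the limit of > 30000 nM in this assay, at which 1 of the 3 values shown sits). Compound 2 `NC(=O)c1cnc2ccc(-c3cccnc3)cc2c1NC1CCCCC1` gives 132 nM, the lower of the two actual numbers in hand. Compound 3 `CCC(CC)CNc1c(C(N)=O)cnc2ccc(-c3cncnc3)cc12`, which carries an open chain on its amino link and a different pendant aromatic ring, gives 1840 nM, a gap from compound 2 that lies beyond the usual scatter. Among the measured compounds shown here, no pair of measured compounds differs in a single place, so no isolated step is available.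

Compound 4 `CCC(CC)COc1c(C(N)=O)cnc2ccc(-c3cccnc3)cc12` is the next compound to be measured. It differs from compound 2 in one place: 2-ethylbutoxy in place of cyclohexylamino on an aromatic carbon. The hydrogen-bond donor of the cyclohexylamino group is lost and the attached carbon chain becomes open. In this assay compound 3, with its open chain, already sits well above compound 2, and the loss of the donor is expected to cost further. A loss is therefore expected on this step, a 23-fold higher number from compound 2 to compound 4 (1.36 log units; beyond the scatter). Compound 4 is expected to give about 3000 nM in this assay, with a likely range from 600 nM to 15000 nM.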

Compound 4, half-maximal inhibitory concentration: > 30000 nM
Compound 4 gave a limit, no number; the forecaster's own chance of this, stated with the estimate: 10%; at least 10-fold (1.00 log units) between middle value and limit.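

At this position, on the aromatic carbon opposite the ring nitrogen and ortho to a carbamoyl group, the series now has its first isolated change: in this assay, 2-ethylbutoxy in place of cyclohexylamino gives an at least 220-fold higher number from compound 2 to compound 4 (2.35 log units; beyond the scatter). This step is only a lower bound on the loss, because compound 4 gives a limit of the assay and not a number: the limit of > 30000 nM in this assay, at which 2 of the 4 values shown sit.

Among the compounds shown here, the position therefore does not accept this exchange of a cyclohexylamino group for a 2-ethylbutoxy group, but the single step removes the ring and the hydrogen-bond donor together and cannot show which loss matters, or whether both do.

Open questions remain on both parts of the change: cyclohexyloxy on the core of compound 2 would keep the ring and change only the link, while 2-ethylbutylamino on that core would keep the nitrogen link and open the ring. The true size of the step also stays unread while compound 4 is known only as a limit.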